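Chloro to Fluoro Swap on Two Related Cores

A few compounds are considered here, and "the series" means these few. Any claim that something is new, unique, unknown or untested is made for them only; others in the source may bear on it.

compound 1 `O=C(Nc1cnc(-n2nccn2)c(Cl)c1)Nc1cnc2cc(Cl)ccc2c1C1CC1`: > 20000 nM (a limit)
compound 2 `O=C(Nc1cnc(-n2nccn2)c(Cl)c1)Nc1cnc2ccc(Cl)cc2c1C1CC1`: 990 nM
compound 3 `O=C(Nc1cnc(-n2nccn2)c(Cl)c1)Nc1cnc2cc(F)ccc2c1C1CC1`: 900 nM

In a functional assay on OCI-Ly3 cells (Homo sapiens) for antiproliferative activity (a higher number here means that more compound is needed for the effect, a lower number that less compound is needed), compound 1 gives only a limit, > 20000 nM, which is the limit of > 20000 nM in this assay, at which 1 of the 3 values shown sits. Compound 3 gives 900 nM in this assay, and compound 2 gives 990 nM; these two lie within the scatter of each other. The change fluoro in place of chloro on an aromatic carbon produced an at least 22-fold lower number from compound 1 to compound 3 (1.34 log units; beyond the scatter). The difference between the core of compound 1 and the core of compound 2 is not broken down here. Compound 4 `O=C(Nc1cnc(-n2nccn2)c(Cl)c1)Nc1cnc2ccc(F)cc2c1C1CC1` differs from compound 2 by fluoro in place of chloro on an aromatic carbon, the same change at a place described in the same words. That reasoning rests on compound 2 at 990 nM, a measured number, so a smaller step than an at least 22-fold lower number from compound 1 to compound 3 (1.34 log units; beyond the scatter) is expected. Compound 4 is therefore expected to show a 1.7-fold lower number from compound 2 to compound 4 (0.22 log units; within the scatter). Compound 4 is estimated at 600 nM, between 200 nM and 2000 nM.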

Compound 4, half-maximal effective concentration: 720 nM
For compound 4 the middle estimate is 1.2-fold (0.08 log units) below the measured one, and the stated range covers the measured number.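

In this assay, fluoro in place of chloro on an aromatic carbon gives a 1.4-fold lower number from compound 2 to compound 4 (0.14 log units; within the scatter), so the large step seen on the core of compound 1 does not carry over in size to the core of compound 2: the same change on two cores in this assay, an at least 22-fold lower number (1.34 log units; beyond the scatter) from compound 1 to compound 3 and a 1.4-fold lower number (0.14 log units; within the scatter) from compound 2 to compound 4, at least 16-fold (1.20 log units) apart, beyond the scatter of two such steps Compound 1 gives only a limit, so the larger step has no exact size: the limit of > 20000 nM in this assay, at which 1 of the 4 values shown sits. The data do not show why the two cores differ, and two cores give no rule for any further core in this series.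

The compounds shown leave open how an amine or a methoxy group would fare on the same aromatic carbon. Only chloro and fluoro appear there.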